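This account rests on a few compounds, and the source may have more. Where it says the series, first, only, none or still open, it means among the compounds named here.

In an assay for inhibition of ectonucleoside triphosphate diphosphohydrolase 8 (Homo sapiens), read by malachite green, with a stated time of 10 min (a lower number here means a stronger inhibitor, a higher number a weaker inhibitor), the measured compounds stand as follows.

Compound 1, `FC(F)(F)c1nc2c(Br)cccc2c(Cl)c1Br`, gives > 300000 nM, which is a limit of this assay rather than a number.
Compound 2, `COc1ccc(-c2cccc3c(Cl)c(Br)c(C(F)(F)F)nc23)cc1`, gives > 300000 nM, again a limit.
Compound 3, `FC(F)(F)c1ccc(-c2cccc3c(Cl)c(Br)c(C(F)(F)F)nc23)cc1`, gives > 300000 nM, also a limit.

Compound 2 therefore stands at a limit of this assay, not at a number, and the two other measured compounds stand at the same limit, so that (the limit of > 300000 nM in this assay, at which 3 of the 3 values shown sit). The step that the two limits leave unreadable from compound 1 to compound 2 and the step that the two limits leave unreadable from compound 2 to compound 3 are both unreadable, since each has a limit at both ends; neither says whether the replacement of one group by another moved the inhibition at all.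

Compound 4, `N#Cc1cccc(-c2cccc3c(Cl)c(Br)c(C(F)(F)F)nc23)c1`, is yet to be measured in this assay. It differs from compound 2 by 3-cyanophenyl in place of 4-methoxyphenyl on an aromatic carbon. For the measured compounds named here, no measured step gives a readable size that bears on this change. What is known is that compound 2 sits at a limit, and that the step from compound 2 to compound 3, with one aryl substituent swapped for another, left the limit in place. Compound 4 is thus expected to remain at the limit as well, with an estimate of 300000 nM and a range from 100000 nM to 1000000 nM. The step of a number no higher from compound 2 to compound 4 (the limit leaves the size open) is expected to be none that the assay can read.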

Compound 4, half-maximal inhibitory concentration: > 300000 nM
Compound 4 gave a limit, no number; the forecaster's own chance of this, stated with the estimate: 85%; the middle value sits exactly at the limit.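

In this assay compound 4 gives > 300000 nM, which is a limit and not a number. The steps to compound 4 from compound 1 and from compound 2 therefore cannot be read, as each has a limit at both ends: the limit of > 300000 nM in this assay, at which 4 of the 4 values shown sit.

The compounds shown leave open whether any of these replacements on the shared core changes the inhibition at all.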